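A few compounds are considered here, and "the series" means these few. Any claim that something is new, unique, unknown or untested is made for them only; others in the source may bear on it.

Measured compounds in an assay on BaF3 cells for inhibition of proto-oncogene tyrosine-protein kinase receptor Ret variant V804M (Homo sapiens), read by MTT assay, with a stated time of 48 h; on this read-out higher numbers stand for weaker inhibition of growth and lower numbers for stronger inhibition of growth:
compound 1 `CC(C)n1nc(-c2ccon2)c2c(N)ncnc21` gives 8940 nM
compound 2 `CC(C)n1nc(-c2cc(C(C)(C)C)on2)c2c(N)ncnc21` gives 7310 nM
compound 3 `CC(C)n1nc(-c2cc(-c3ccccc3)on2)c2c(N)ncnc21` gives 4970 nM

Compound 3 stands with the other two inside a narrow band: the steps of a 1.8-fold lower number from compound 1 to compound 3 (0.25 log units; within the scatter) and a 1.5-fold lower number from compound 2 to compound 3 (0.17 log units; within the scatter) are both within the scatter, as is a 1.2-fold lower number from compound 1 to compound 2 (0.09 log units; within the scatter), so none of the three can be set apart from the others in this assay.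

Compound 4 `CCc1cc(-c2nn(C(C)C)c3ncnc(N)c23)no1` has not yet been measured. It differs from compound 3 by ethyl in place of phenyl on an aromatic carbon. For the measured compounds named here, the steps that bear on this change are those that put the phenyl in place at the same aromatic carbon: from hydrogen, a 1.8-fold lower number from compound 1 to compound 3 (0.25 log units; within the scatter), and from tert-butyl, a 1.5-fold lower number from compound 2 to compound 3 (0.17 log units; within the scatter). Both were within the scatter, and the ethyl group of compound 4 sits in size between hydrogen and tert-butyl. Going back from phenyl to a small alkyl is therefore expected to move the number, if at all, slightly upward, with a step of a 1.5-fold higher number from compound 3 to compound 4 (0.18 log units; within the scatter) expected. Compound 4 is thus estimated to give 7500 nM, within a range of 3500 nM to 16000 nM.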

Compound 4, concentration for 50% growth inhibition: 5770 nM
Compound 4: the middle estimate sits 1.3-fold (0.11 log units) above what was measured; measured number inside the range.
By their numbers in this assay, from the lowest: compounds 3, 4, 2 and 1 (each within the scatter of the next).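

In this assay, ethyl on the aromatic carbon next to the ring oxygen falls in the same narrow band as the other three groups: putting it in place of phenyl gives a 1.2-fold higher number from compound 3 to compound 4 (0.06 log units; within the scatter), in place of tert-butyl gives a 1.3-fold lower number from compound 2 to compound 4 (0.10 log units; within the scatter), and in place of hydrogen gives a 1.5-fold lower number from compound 1 to compound 4 (0.19 log units; within the scatter), all within the scatter. Removing the six-membered aromatic ring of the phenyl therefore leaves no readable change, so across hydrogen, ethyl, tert-butyl and phenyl this position shows no difference that the assay can resolve. Nothing available bears on why the position behaves this way.

On these data alone, all four compounds carry only hydrogen or a hydrocarbon group on this carbon, so whether an amine, a carboxylic acid or an amide there would stay within this band remains open. As far as these compounds go, it also remains open whether any group on this carbon can move the number beyond the scatter.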